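Replacing amino with diethylamino in compound 3

This account rests on a few compounds, and the source may have more. Where it says the series, first, only, none or still open, it means among the compounds named here.

Measured in a functional assay on HCT-116 cells (Homo sapiens) for inhibition; on this read-out higher numbers stand for weaker inhibition and lower numbers for stronger inhibition:
- Compound 1 `COCCOc1cc(/C=C/c2ccc3ccccc3c2)ccc1OC`: > 5000 nM, a limit.
- Compound 2 `COc1ccc(/C=C/c2ccc3ccccc3c2)cc1F`: > 5000 nM, a limit.
- Compound 3 `COc1ccc(/C=C/c2ccc3ccccc3c2)cc1N`: 1820 nM.

Within the data shown here, compound 3 gives 1820 nM, the only actual number in this small set. The other two results sit at one limit (the limit of > 5000 nM in this assay, at which 2 of the 3 values shown sit).

Compound 4 `CCN(CC)c1cc(/C=C/c2ccc3ccccc3c2)ccc1OC` carries diethylamino in place of amino on an aromatic carbon. Among the measured compounds shown here, no measured step brings in diethylamino, so the evidence is indirect. For the measured compounds named here, two steps bear on the change: an at least 2.7-fold lower number from compound 1 to compound 3 (0.43 log units; beyond the scatter) and an at least 2.7-fold lower number from compound 2 to compound 3 (0.43 log units; beyond the scatter). In both, amino enters and the number falls, whereas here amino leaves. The step that the two limits leave unreadable from compound 1 to compound 2 adds nothing on size. Compound 4 is therefore expected to lose ground in this assay, by about as much as those two steps show. The expected change is a 2.7-fold higher number from compound 3 to compound 4 (0.44 log units; beyond the scatter). For compound 4 the estimated value is 5000 nM, with an expected range from 1800 nM to 15000 nM.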

Compound 4, half-maximal inhibitory concentration: > 5000 nM
Compound 4 was reported as a limit; the forecaster's own chance of this, stated with the estimate: 55%; the middle value lies on the limit itself.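

Diethylamino in place of amino on this aromatic carbon, ortho to a methoxy group, gives an at least 2.7-fold higher number from compound 3 to compound 4 (0.43 log units; beyond the scatter) in this assay, so a nitrogen at this position does not by itself hold the number down. Diethylamino differs from amino both in size and in carrying no hydrogen-bond donor, and this single step cannot separate the two. The steps from compound 1 and compound 2 to compound 4 join two limits and cannot be read: the limit of > 5000 nM in this assay, at which 3 of the 4 values shown sit.

From the compounds shown here alone, whether compound 3, at 1820 nM, keeps its number when methylamino or dimethylamino replaces amino on this carbon remains open. Also open, going by these compounds, is whether a hydroxyl group at this position, with no nitrogen, comes close to amino.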